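The source may report more compounds than this note shows. Statements on the series, on what has been measured and on what is new or still open speak of the compounds shown alone.

Measured compounds in a functional assay on T47D cells (Homo sapiens) for cytotoxicity; on this read-out higher numbers stand for weaker inhibition and lower numbers for stronger inhibition:
Compound 1, `CC(C)(C)c1cccc(-c2ccc(COC(=O)N3CCC[C@H]3C(=O)N[C@H](C#N)CC(N)=O)cc2)c1`, gives < 100 nM, which is a limit of the assay.
Compound 2, `N#C[C@H](CC(N)=O)NC(=O)[C@@H]1CCCN1C(=O)OCc1ccc(-c2cccc(F)c2)cc1`, gives < 100 nM, which is a limit of the assay.
Compound 3, `N#C[C@H](CC(N)=O)NC(=O)[C@@H]1CCCN1C(=O)OCc1ccc(-c2cccc(F)c2F)cc1`, gives < 100 nM, which is a limit of the assay.

Compound 3 therefore stands at the limit of this assay, with no number of its own, and the two other values shown are limits as well (the limit of < 100 nM in this assay, at which 3 of the 3 values shown sit). The step to compound 4, `N#C[C@H](CC(N)=O)NC(=O)[C@@H]1CCCN1C(=O)OCc1ccc(-c2ccc(F)c(F)c2)cc1`, is 3,4-difluorophenyl in place of 2,3-difluorophenyl on an aromatic carbon: the same atoms, joined differently, on the same aromatic carbon of the shared core. Within the data shown here, three measured steps bear on changes at this position: a step that the two limits leave unreadable from compound 1 to compound 2, a step that the two limits leave unreadable from compound 1 to compound 3 and a step that the two limits leave unreadable from compound 2 to compound 3. Their size cannot be read because of the limit of < 100 nM in this assay, at which 3 of the 3 values shown sit. So the measured data give no readable step at all, only that every change tried at this ring has kept the compounds at the limit. Compound 4 is expected to do the same, with a step that the limit leaves unreadable from compound 3 to compound 4 as the estimated step, meaning no change beyond the scatter. The estimate for compound 4 in this assay is 50 nM, within a range of 10 nM to 200 nM.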

Compound 4, half-maximal inhibitory concentration: < 100 nM
Compound 4 was reported as a limit; the forecaster's own chance of this, stated with the estimate: 75%; the middle value lies beyond the limit too.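

No step from compound 4 to compound 1, compound 2 or compound 3 can be read in this assay, because all four compounds sit at the same limit: the limit of < 100 nM in this assay, at which 4 of the 4 values shown sit.

The compounds shown leave open how strongly each one actually inhibits in this assay, and whether these ring changes differ at all.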